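Amino on the shared core: expected shift in cell inhibition

The compounds below may be only part of what the source reports. "The series", "measured", "known", "first", "only" and "open" are said of these compounds alone.

Compound 1 `COc1ncnc2c1c(-c1ccsc1)cn2[C@@H]1O[C@H](CO)[C@@H](O)[C@H]1O` and compound 3 `COc1ncnc2c1c(-c1cccs1)cn2[C@@H]1O[C@H](CO)[C@@H](O)[C@H]1O` share one core; they differ by thiophen-2-yl in place of thiophen-3-yl on an aromatic carbon. In an ADME assay on BJ cells (Homo sapiens), read by MTT assay, with a stated time of 72 h (on this read-out higher numbers stand for weaker inhibition and lower numbers for stronger inhibition), compound 1 gives 64300 nM, and compound 3 gives 62800 nM; the step between them is a 1.0-fold lower number from compound 1 to compound 3 (0.01 log units; within the scatter). Compound 2 `COc1nc(N)nc2c1c(-c1ccsc1)cn2[C@@H]1O[C@H](CO)[C@@H](O)[C@H]1O` carries the change (amino in place of hydrogen on an aromatic carbon). In this assay compound 2 reaches only a limit, > 100000 nM. The step is an at least 1.5-fold higher number from compound 1 to compound 2 (0.19 log units; that floor lies within the scatter), which rests on (the limit of > 100000 nM in this assay, at which 1 of the 3 values shown sits). Compound 4 `COc1nc(N)nc2c1c(-c1cccs1)cn2[C@@H]1O[C@H](CO)[C@@H](O)[C@H]1O` is not yet measured; it differs from compound 3 by amino in place of hydrogen on an aromatic carbon, the same change, with the place described in identical words. For compound 4 in this assay the expected step is a 1.8-fold higher number from compound 3 to compound 4 (0.24 log units; within the scatter), resting on the earlier step of an at least 1.5-fold higher number from compound 1 to compound 2 (0.19 log units; that floor lies within the scatter). Compound 4 is therefore estimated at 110000 nM, between 60000 nM and 250000 nM, and a limit rather than a number is expected to be the likely outcome.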

Compound 4, half-maximal inhibitory concentration: 99900 nM
Beside the measured number, compound 4's estimate is 1.1-fold (0.04 log units) above it; measured number inside the range.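

In this assay, amino in place of hydrogen on an aromatic carbon gives a 1.6-fold higher number from compound 3 to compound 4 (0.20 log units; within the scatter), and the earlier step can be set beside this one only through a limit: the same change on two cores in this assay, an at least 1.5-fold higher number (0.19 log units; that floor lies within the scatter) from compound 1 to compound 2 and a 1.6-fold higher number (0.20 log units; within the scatter) from compound 3 to compound 4; the limit leaves it open whether they differ. The two steps are compatible with the change carrying from one core to the other, but they do not show that it does, and they show no step beyond the scatter: the limit of > 100000 nM in this assay, at which 1 of the 4 values shown sits. Thiophen-2-yl in place of thiophen-3-yl on the amino-bearing core gives a number no higher from compound 2 to compound 4 (the limit leaves the size open) and this step cannot be read: the same change on two cores in this assay, a 1.0-fold lower number (0.01 log units; within the scatter) from compound 1 to compound 3 and a number no higher (the limit leaves the size open) from compound 2 to compound 4; the limit leaves it open whether they differ.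

From the compounds shown here alone, it remains open whether a methylamino or a hydroxyl group between the two ring nitrogen atoms would behave as amino does. Also open, going by these compounds, is whether either step holds with a phenyl ring in place of the thiophene.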